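4-hydroxyphenyl to 4-methoxyphenyl

The compounds below may be only part of what the source reports. "The series", "measured", "known", "first", "only" and "open" are said of these compounds alone.

In a functional assay on HL-60 cells (Homo sapiens) for cytotoxicity, read by WST assay, with a stated time of 48 h (on this read-out lower numbers stand for an effect already at smaller amounts and higher numbers for an effect only at larger amounts of compound), compound 1 `O=C1OC[C@H](Cc2ccccc2F)[C@H]1Cc1ccc(Cl)c(Cl)c1` gives 28000 nM, compound 2 `Cc1cccc(C[C@H]2COC(=O)[C@@H]2Cc2ccc(Cl)c(Cl)c2)c1` gives 22000 nM and compound 3 `O=C1OC[C@H](Cc2ccc(O)cc2)[C@H]1Cc1ccc(Cl)c(Cl)c1` gives 37000 nM. Compound 3 therefore cannot be separated from the other two on these numbers. Compound 4 `COc1ccc(C[C@H]2COC(=O)[C@@H]2Cc2ccc(Cl)c(Cl)c2)cc1` differs from compound 3 as follows: methyl in place of hydrogen on an oxygen on an aromatic ring. This is methyl in place of hydrogen on an oxygen on an aromatic ring, turning hydroxy into methoxy.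

Among the compounds with values here, no measured compound carries the methoxy group, so this change has not been tested directly. The closest evidence is the set of exchanges on the same aromatic group: a 1.3-fold higher number from compound 1 to compound 3 (0.12 log units; within the scatter), a 1.7-fold higher number from compound 2 to compound 3 (0.23 log units; within the scatter) and a 1.3-fold lower number from compound 1 to compound 2 (0.10 log units; within the scatter). All three stay within the scatter, so no step beyond the scatter is expected in this assay. The expected change is a 1.2-fold lower number from compound 3 to compound 4 (0.09 log units; within the scatter), with no direction that the data can support. For compound 4 the estimated value is 30000 nM, with an expected range of 15000 nM to 60000 nM.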

Compound 4, half-maximal effective concentration: 37000 nM
Compound 4: the middle estimate sits 1.2-fold (0.09 log units) below what was measured, and the stated range covers the measured number.
By their numbers in this assay, from the lowest: compounds 2, 1, 3 and 4 (each within the scatter of the next).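

Methyl in place of hydrogen on the oxygen on the aromatic ring gives no change at the digits printed from compound 3 to compound 4 (within the scatter) in this assay and is the first direct reading at this oxygen: the number does not depend on that hydrogen in this read-out. Against the other aromatic groups, the methoxy group shows a 1.7-fold higher number from compound 2 to compound 4 (0.23 log units; within the scatter) and a 1.3-fold higher number from compound 1 to compound 4 (0.12 log units; within the scatter) and so adds to the flat picture: none of the four aromatic groups on this saturated chain carbon can be separated from the others on these numbers. Nothing available explains this flat result.

Open, on these data alone, is whether an amine or a carboxylic acid on this aromatic ring would move the number beyond the scatter. Open too, as far as these compounds go, is whether a longer chain in place of methyl on the oxygen would do so.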